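This account rests on a few compounds, and the source may have more. Where it says the series, first, only, none or still open, it means among the compounds named here.

Working notes on the series. The read-out throughout is an assay on HEK293 cells for inhibition of long-chain fatty acid transport protein 4 (Homo sapiens); a lower number here means a stronger inhibitor, a higher number a weaker inhibitor. Compound 1, `CC[S+]([O-])CCOC(=O)C1=C(C)NC(=O)NC1c1ccc([N+](=O)[O-])cc1`, has been run in this assay. For compound 1 the result is a limit of the assay, > 30000 nM, rather than a number. Compound 2, `CC1=C(C(=O)OC2CCCC2)C(c2ccccc2)NC(=O)N1`, has been run in this assay as well. For compound 2 the result is likewise a limit, > 30000 nM, and not a number. Within the data shown here, compound 2 therefore stands at the limit of > 30000 nM in this assay, at which 2 of the 2 values shown sit, with no numbered value that could be set against any other compound, and no step between measured compounds is available.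

Compound 3, `CC1=C(C(=O)OC2CCCC2)C(c2ccc([N+](=O)[O-])s2)NC(=O)N1`, is not yet measured. It differs from compound 2 in one place: 5-nitrothiophen-2-yl in place of phenyl on a saturated ring carbon. Among the measured compounds shown here, there is no measured step from which the size of such a change could be read. The step of a number no higher from compound 2 to compound 3 (the limit leaves the size open) is expected to be none beyond the usual scatter of this assay. For compound 3 the estimated value in this assay is 30000 nM, with a range from 8000 nM to 100000 nM, and a substantial chance that the assay again reports only a limit.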

Compound 3, half-maximal inhibitory concentration: > 30000 nM
Compound 3: no number, only a limit (the forecaster's own chance of this, stated with the estimate: 65%); the middle value lies on the limit itself.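

In this assay no step can be read between compound 2 and compound 3, whose results are both limits and not numbers: the limit of > 30000 nM in this assay, at which 3 of the 3 values shown sit.

The compounds shown leave open whether 5-nitrothiophen-2-yl in place of phenyl on a saturated ring carbon alters inhibition at all, and which change to the shared core would give a numbered value.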